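The source may hold more compounds than are shown below. What is called first, only, known or untested is meant among the compounds shown, and "the series" means these compounds.

The measured compounds: compound 1 `ClCc1ccc(Cn2cnc3c(Cl)ncnc32)cc1` with 70800 nM; compound 3 `ClCc1ccc(Cn2cnc3c(Cl)nc(Cl)nc32)cc1` with 56200 nM; compound 2 `ClCc1cccc(Cn2cnc3ncnc(Cl)c32)c1` with "not determined" (no result reported).

In a functional assay on SF-539 cells (Homo sapiens) for cytotoxicity, read by sulforhodamine B assay, with a stated time of 48 h (on this read-out lower numbers stand for higher toxicity in this test and higher numbers for lower toxicity in this test), compound 1 gives 70800 nM and compound 3 gives 56200 nM; the step of a 1.3-fold lower number from compound 1 to compound 3 (0.10 log units; within the scatter) corresponds to chloro in place of hydrogen on an aromatic carbon. Compound 2 and compound 1 have the same atoms joined differently; the difference between the two cores is not broken down here. Compound 4 `ClCc1cccc(Cn2cnc3nc(Cl)nc(Cl)c32)c1` is not yet measured. It differs from compound 2 by chloro in place of hydrogen on an aromatic carbon, the same change as from compound 1 to compound 3, at a place described in the same words. Because the step of a 1.3-fold lower number from compound 1 to compound 3 (0.10 log units; within the scatter) lies within the scatter, the step from compound 2 to compound 4 in this assay is expected to be similarly small. Compound 2 has no number, so the expectation rests on compounds 1 and 3 alone. Compound 4 is estimated at 60000 nM, between 20000 nM and 150000 nM.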

Compound 4, concentration lethal to 50% of the cells: 1620 nM
Estimate against measurement, compound 4: 37-fold (1.57 log units) above; the whole stated range lies above it.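

Compound 2 has no number in this assay and the step to compound 4 cannot be read. The compounds shown leave open how much of the result for compound 4 goes with the added chloro and how much with its core. No evidence at hand bears on this result.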